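Methyl for Fluorophenyl on a Limit-Bound Series

The source may hold more compounds than are shown below. What is called first, only, known or untested is meant among the compounds shown, and "the series" means these compounds.

Compound 1 `CS(=O)(=O)c1ccc(C(=O)NCCCC(=O)N2Cc3ccccc3C2)cc1[N+](=O)[O-]`: in an assay on isolated protein for inhibition of thyroid hormone receptor alpha (Homo sapiens), read by fluorescence polarization (on this read-out higher numbers stand for weaker inhibition and lower numbers for stronger inhibition), compound 1 gives > 60000 nM.
Compound 2 `CS(=O)(=O)c1ccc(C(=O)N2CCC(C(=O)N3CCN(c4ccc(F)cc4)CC3)CC2)cc1[N+](=O)[O-]`: in this assay compound 2 gives > 60000 nM.
Compound 3 `CS(=O)(=O)c1ccc(C(=O)N2CCC(C(=O)N(Cc3ccccc3)Cc3ccccc3)CC2)cc1[N+](=O)[O-]`: in this assay compound 3 gives > 60000 nM.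

The value of compound 1 is a limit of the assay, not a number. The value of compound 2 is likewise a limit. The value of compound 3 is also a limit. Compound 2 thus stands at the edge of what the assay reports, (the limit of > 60000 nM in this assay, at which 3 of the 3 values shown sit). Compound 4 `CN1CCN(C(=O)C2CCN(C(=O)c3ccc(S(C)(=O)=O)c([N+](=O)[O-])c3)CC2)CC1` differs from compound 2 in one place: methyl in place of 4-fluorophenyl on an amine nitrogen in a ring. Going by the values given here, no measured step gives a guide for this change, so no shift beyond the usual scatter is expected in this assay. The expected step is a step that the limit leaves unreadable from compound 2 to compound 4. Compound 4 is expected to give 80000 nM, between 20000 nM and 300000 nM, most likely again as a limit.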

Compound 4, half-maximal inhibitory concentration: > 60000 nM
Compound 4 ended at the assay's limit (the forecaster's own chance of this, stated with the estimate: 85%); the middle value does not contradict the limit.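

No step can be read from compound 2 to compound 4, since both values are limits of the assay: the limit of > 60000 nM in this assay, at which 4 of the 4 values shown sit. Whether methyl or 4-fluorophenyl at this place changes inhibition at all stays open, since none of the compounds shown gives a readable value.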